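Pyridin-2-yl gives way to 3-methoxyphenyl on the shared core

The compounds below may be only part of what the source reports. "The series", "measured", "known", "first", "only" and "open" are said of these compounds alone.

- Compound 1 `COc1ccccc1-c1nnc(SC2=CS(=O)(=O)c3ccccc32)o1` gives 16000 nM here
- Compound 2 `O=S1(=O)C=C(Sc2nnc(-c3ccccn3)o2)c2ccccc21` gives 24000 nM here

Among the measured compounds shown here, in an ADME assay on HepG2 cells (Homo sapiens) for cytotoxicity, read by fluorescence and resazurin assay, with a stated time of 24 h (on this read-out lower numbers stand for higher toxicity in this test and higher numbers for lower toxicity in this test), compound 2 gives 24000 nM and stands within the scatter of compound 1, the only other measured compound. Compound 3 `COc1cccc(-c2nnc(SC3=CS(=O)(=O)c4ccccc43)o2)c1` differs from compound 2 by one change: 3-methoxyphenyl in place of pyridin-2-yl on an aromatic carbon with 3-methoxyphenyl in place of pyridin-2-yl on an aromatic carbon. For the measured compounds named here, the one measured step bearing on this (a 1.5-fold higher number from compound 1 to compound 2 (0.18 log units; within the scatter)) exchanged 2-methoxyphenyl for pyridin-2-yl at that same carbon, so no step beyond the scatter is expected in this assay here. The expected step (a 1.3-fold lower number from compound 2 to compound 3 (0.12 log units; within the scatter)) is only an estimate. Compound 3 is estimated at 18000 nM with an expected range of 8000 nM to 40000 nM in this test.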

Compound 3, half-maximal cytotoxic concentration: 20000 nM
The estimate for compound 3 lay 1.1-fold (0.05 log units) below the measured number, within the range that was stated.
By their numbers in this assay, from the lowest: compounds 1, 3 and 2 (each within the scatter of the next).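

In this assay, 3-methoxyphenyl in place of pyridin-2-yl gives a 1.2-fold lower number from compound 2 to compound 3 (0.08 log units; within the scatter), and 3-methoxyphenyl in place of 2-methoxyphenyl gives a 1.3-fold higher number from compound 1 to compound 3 (0.10 log units; within the scatter). At this aromatic carbon of the shared core, 2-methoxyphenyl, 3-methoxyphenyl and pyridin-2-yl therefore cannot be told apart on this read-out, so moving the methoxy group adds no separation either. No evidence is available that bears on this result.

As far as these compounds go, whether a group of another kind at this carbon, such as an aminomethyl group or a carboxylic acid on the ring, would give a step beyond the scatter remains open.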